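Ethyl for methyl on the core of compound 1

This account rests on a few compounds, and the source may have more. Where it says the series, first, only, none or still open, it means among the compounds named here.

Measured so far:
compound 1 `COCc1cc(OC)c(-c2cccc3c(N(CC4CCOCC4)CC4CC4)c(C)nn23)c(OC)c1`: 120 nM
compound 2 `COCc1cc(OC)c(-c2cccc3c(N(CC4CC4)CC4OCCCO4)c(SC)nn23)c(OC)c1`: 113 nM
compound 3 `CCc1nn2c(-c3c(C)cc(C)cc3OC)cccc2c1N(CC1CC1)CC1CCOC1`: 38 nM

In an assay on HEK293 cells for displacement of a labelled ligand from corticotropin-releasing factor receptor 1 (Homo sapiens), read by scintillation counting, with a stated time of 2 h (a lower number here means a stronger inhibitor, a higher number a weaker inhibitor), compound 1 gives 120 nM, the highest of the three numbers; compound 2 stands within the scatter of it, while compound 3, which differs in several places, shows a lower number beyond the scatter. Compound 4 `CCc1nn2c(-c3c(OC)cc(COC)cc3OC)cccc2c1N(CC1CCOCC1)CC1CC1` differs from compound 1 by methyl in place of hydrogen on a saturated chain carbon bound to an aromatic carbon. Among the measured compounds shown here, no two measured compounds differ only at this position, so no step for this change is known. Compound 3 carries the ethyl and gives 38 nM, but its other differences leave that comparison unclear. The expected step from compound 1 to compound 4 is a 1.5-fold lower number from compound 1 to compound 4 (0.18 log units; within the scatter), a small shift downward, close to the scatter. Compound 4 is expected at 80 nM, between 35 nM and 180 nM.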

Compound 4, half-maximal inhibitory concentration in the corticotropin-releasing factor receptor 1 assay: 50 nM
Compound 4: middle estimate off by 1.6-fold (0.20 log units), on the high side; low and high end bracket the measured number.
By their numbers in the corticotropin-releasing factor receptor 1 assay, from the lowest: compounds 3 and 4 (each within the scatter of the next); then compounds 2 and 1 (each within the scatter of the next).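

In the corticotropin-releasing factor receptor 1 assay, methyl to ethyl on the shared core gives a 2.4-fold lower number from compound 1 to compound 4 (0.38 log units; beyond the scatter), the first step read at this position, and it lies beyond the scatter. The earlier compounds shown here could not show this, since compound 2 and compound 3 differ from compound 1 in several places. In a physicochemical assay for solubility, in phosphate buffer, measured as kinetic solubility (a higher number here means a more soluble compound, a lower number a less soluble compound), compound 1 gives 21000 nM and compound 4 gives 4800 nM, and the same change also comes with lower solubility: the measured solubility of compound 1, 21000 nM, and of compound 4, 4800 nM, a 4.4-fold lower number (0.64 log units; beyond the scatter)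

Open, from the compounds shown here alone, is what a longer chain such as propyl, or an amine, would do at this position in either assay. Also open, going by these compounds, is whether the step holds with other groups elsewhere on the core.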